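The source may hold more compounds than are shown below. What is called first, only, known or untested is meant among the compounds shown, and "the series" means these compounds.

Measured so far:
Compound 1 `Nc1ccccc1NC(=O)CCCNCC(=O)Nc1ccc(Cl)cc1`: 75000 nM
Compound 2 `Cc1ccc(NC(=O)CNc2ccc(C(=O)Nc3ccccc3N)cc2)cc1`: > 100000 nM

Among the compounds with values here, in a functional assay on U-251 cells (Homo sapiens) for inhibition, read by MTT assay, with a stated time of 2 days (on this read-out lower numbers stand for stronger inhibition of growth and higher numbers for weaker inhibition of growth), compound 1 gives 75000 nM, the only true number available so far. Compound 2 reads > 100000 nM, which is a limit of the assay and not a number. Also worth keeping in view is the limit of > 100000 nM in this assay, at which 1 of the 2 values shown sits. Compound 1 therefore offers a single reference point, and no comparison of size can yet be drawn from compound 2.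

The next compound to be tested is compound 3 `COc1ccc(NC(=O)CNCCCC(=O)Nc2ccccc2N)cc1`. It keeps the core of compound 1 and carries methoxy in place of chloro on an aromatic carbon, para to a large group: methoxy in place of chloro on an aromatic carbon. The same difference can be read as 4-chlorophenyl to 4-methoxyphenyl. Within the data shown here, no measured pair shows this kind of change, so the expectation in this assay is for no step beyond the scatter, in either direction. That expectation rests on compound 1 at 75000 nM alone. The expected step is a 1.1-fold higher number from compound 1 to compound 3 (0.03 log units; within the scatter). For compound 3 the estimated value is 80000 nM, with an expected range of 40000 nM to 150000 nM.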

Compound 3, concentration for total growth inhibition: > 100000 nM
Compound 3 was reported as a limit (the forecaster's own chance of this, stated with the estimate: 35%); at least 1.2-fold (0.09 log units) between middle value and limit.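

On an aromatic carbon, para to a large group, this position now has its first measured change: in this assay, methoxy in place of chloro gives an at least 1.3-fold higher number from compound 1 to compound 3 (0.12 log units; that floor lies within the scatter). The value of compound 3 is a limit of the assay and not a number, so this step is only a floor, and it does not show whether the change moves the read-out beyond the usual scatter. What it does show is that compound 3, unlike compound 1, gives no true number and joins compound 2 at the assay's limit: the limit of > 100000 nM in this assay, at which 2 of the 3 values shown sit.

The compounds shown leave open how far compound 3 truly lies from compound 1, and therefore how much the exchange of chloro for methoxy matters at this position. They also leave open what a fluoro, a nitrile or an amine would do at the same place on the core of compound 1, and whether a longer chain would bring a number clearly lower than that of compound 1.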